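A Small Halogen Exchange and What It May Do

This account rests on a few compounds, and the source may have more. Where it says the series, first, only, none or still open, it means among the compounds named here.

Of the compounds shown here, three sharing one core have been measured in an ADME assay on liver (Mus musculus) for metabolic stability, read by LC-MS, using microsomes and NADPH; on this read-out lower numbers stand for a less stable compound and higher numbers for a more stable compound. Compound 1 `COc1cc(CN(CC(C)C)C(CC(=O)O)c2ccc3c(c2)CCO3)ccc1OCCN1C(=O)CCC1=O` gives 100%, compound 2 `COc1cc(CN(CC(C)C)C(CC(=O)O)c2ccc(Cl)cc2)ccc1OCCN1C(=O)CCC1=O` gives 69%, and compound 3 `COc1cc(CN(CC(C)C)C(CC(=O)O)c2ccc(Cl)cc2Cl)ccc1OCCN1C(=O)CCC1=O` gives 67%. Compound 3 therefore stands level with compound 2, and both sit well under compound 1.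

Compound 4 `COc1cc(CN(CC(C)C)C(CC(=O)O)c2ccc(Cl)c(F)c2)ccc1OCCN1C(=O)CCC1=O` differs from compound 3 in one group: 4-chloro-3-fluorophenyl in place of 2,4-dichlorophenyl on a saturated chain carbon bound to an amine nitrogen and a saturated chain carbon. The 4-chloro-3-fluorophenyl group enters on a saturated chain carbon bound to an amine nitrogen and a saturated chain carbon.

The closest evidence is a small change at that same group, a number 2 percentage points lower from compound 2 to compound 3 (within the scatter), which stays within the scatter. Much larger steps, a number 31 percentage points lower from compound 1 to compound 2 (beyond the scatter) and a number 33 percentage points lower from compound 1 to compound 3 (beyond the scatter), came from removing a group with an additional five-membered non-aromatic ring, and nothing comparable happens here. Among the compounds with values here, no measured compound carries fluoro, so that part remains untested.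

The expected result is a number 3 percentage points higher from compound 3 to compound 4 (within the scatter), an estimated step within the scatter. Compound 4 is estimated at 70%, with an expected range of 55% to 85%.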

Compound 4, percent of the compound remaining: 57%
The estimate for compound 4 lay 13 percentage points above the measured number; low and high end bracket the measured number.
By their numbers in this assay, from the lowest: compounds 4, 3 and 2 (each within the scatter of the next, the first and the last beyond it); then compound 1.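

In this assay, the added fluoro gives a number 12 percentage points lower from compound 2 to compound 4 (beyond the scatter), whereas the added chloro gave only a number 2 percentage points lower from compound 2 to compound 3 (within the scatter), so at this group, not every halogen added to the chlorophenyl ring of compound 2 leaves the number within the scatter. Exchanging 2,4-dichlorophenyl for 4-chloro-3-fluorophenyl gives a number 10 percentage points lower from compound 3 to compound 4 (within the scatter), so this exchange alone cannot be told apart from repeat scatter. The gap to the ring system of compound 1 remains wide, at a number 43 percentage points lower from compound 1 to compound 4 (beyond the scatter).

The data shown offer no measurement that explains the effect of the fluoro group. Also open, going by these compounds, is how a phenyl ring carrying a nitrile or a trifluoromethyl group in place of the halogens would read in this assay.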